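Swapping Furan for Pyridine at the Amide Aryl

A few compounds are considered here, and "the series" means these few. Any claim that something is new, unique, unknown or untested is made for them only; others in the source may bear on it.

Three compounds share one core and differ only in the ring attached to the aromatic carbon. In an assay on L cells for inhibition of Protein-serine O-palmitoleoyltransferase porcupine (Mus musculus), read by reporter gene assay, with a stated time of 24 h (a higher number here means that more compound is needed for the effect, a lower number that less compound is needed), compound 1 `O=C(CSc1nc2c(c(=O)n1-c1ccccc1)SCC2)Nc1ccc(-c2cncnc2)cn1` gives 5.5 nM, compound 2 `O=C(CSc1nc2c(c(=O)n1-c1ccccc1)SCC2)Nc1ccc(-c2ccsc2)cn1` gives 2 nM, and compound 3 `O=C(CSc1nc2c(c(=O)n1-c1ccccc1)SCC2)Nc1ccc(-c2ccco2)cn1` gives 3.5 nM. Compound 3 stands second highest of the three, and both the step of a 1.6-fold lower number from compound 1 to compound 3 (0.20 log units; within the scatter) and the step of a 1.8-fold higher number from compound 2 to compound 3 (0.24 log units; within the scatter) stay within the scatter; only a 2.8-fold lower number from compound 1 to compound 2 (0.44 log units; beyond the scatter) reaches beyond it.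

Compound 4 `O=C(CSc1nc2c(c(=O)n1-c1ccccc1)SCC2)Nc1ccc(-c2cccnc2)cn1` carries pyridin-3-yl in place of furan-2-yl on an aromatic carbon. The closest measured guide is a 1.6-fold lower number from compound 1 to compound 3 (0.20 log units; within the scatter), where compound 1 also holds a six-membered ring with ring nitrogen, and that step was within the scatter. No step beyond the scatter is therefore expected in this assay, and compound 4 is estimated to show a 1.3-fold higher number from compound 3 to compound 4 (0.11 log units; within the scatter). The estimate for compound 4 is 4.5 nM, with a range from 2 nM to 10 nM.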

Compound 4, half-maximal effective concentration: 1 nM
Compound 4: the middle estimate sits 4.5-fold (0.65 log units) above what was measured; measured number below the stated range.
By their numbers in this assay, from the lowest: compounds 4, 2, 3 and 1 (each within the scatter of the next, the first and the last beyond it).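

Among these compounds, this position separates two six-membered aromatic rings: pyridin-3-yl and pyrimidin-5-yl differ by a 5.5-fold lower number from compound 1 to compound 4 (0.74 log units; beyond the scatter), the largest step so far, so ring size alone does not set the number. Pyridin-3-yl also improves on furan-2-yl, with a 3.5-fold lower number from compound 3 to compound 4 (0.54 log units; beyond the scatter), while the comparison with thiophen-3-yl gives a 2.0-fold lower number from compound 2 to compound 4 (0.30 log units; within the scatter), so those two cannot be told apart. No measurement here explains these differences.

Open questions remain about pyridin-2-yl and pyridin-4-yl, which would test where the ring nitrogen sits. The effect of an amine or a carboxylic acid on the pyridine ring is also unknown.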